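The source may report more compounds than this note shows. Statements on the series, on what has been measured and on what is new or still open speak of the compounds shown alone.

Measured so far in an assay on HEK293 cells for positive allosteric modulation of metabotropic glutamate receptor 5 (Homo sapiens), read by FLIPR, with a stated time of 1 h; on this read-out lower numbers stand for an effect already at smaller amounts and higher numbers for an effect only at larger amounts of compound:
compound 1 `COc1ccccc1C#Cc1nc2c(s1)C(=O)NCC2`: a limit only, > 10000 nM.
compound 2 `CCN1CCc2nc(C#Cc3ccccc3)sc2C1`: a limit only, > 10000 nM.
compound 3 `Fc1cccc(C#Cc2nc3c(s2)CN(C2CCC2)CC3)c1`: a limit only, > 10000 nM.

Compound 2 thus has no place on a scale of numbers: its value is a limit, and the two other values shown are limits as well (the limit of > 10000 nM in this assay, at which 3 of the 3 values shown sit). Going by the values given here, no step between measured compounds is available. Compound 4 `O=C(C1CC1)N1CCc2nc(C#Cc3ccccc3)sc2C1` differs from compound 2 by cyclopropylcarbonyl in place of ethyl on an amine nitrogen in a ring. With nothing but limits on hand, no direction for this change in this assay can be read from the series; the expected step from compound 2 to compound 4 is an at least 1.2-fold lower number from compound 2 to compound 4 (0.09 log units; that floor lies within the scatter), and another limit is the likelier outcome. Compound 4 is estimated at 8000 nM, range 1000 nM to 30000 nM.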

Compound 4, half-maximal effective concentration: > 10000 nM
Compound 4: a limit, no number; the forecaster's own chance of this, stated with the estimate: 65%; at least 1.2-fold (0.09 log units) between middle value and limit.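

Compound 2 and compound 4 both give only a limit, so no step can be read for cyclopropylcarbonyl in place of ethyl: the limit of > 10000 nM in this assay, at which 4 of the 4 values shown sit.

The compounds shown leave open whether any change on the shared core gives a number rather than a limit.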